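Removing the acetyl and methoxy groups from the phenoxy end

A few compounds are considered here, and "the series" means these few. Any claim that something is new, unique, unknown or untested is made for them only; others in the source may bear on it.

Of the compounds shown here, three built on a shared core have been measured in a functional assay (aorta) with Oryctolagus cuniculus as the target; a lower number here means tighter binding, a higher number weaker binding. Compound 1 `COc1cc(C(C)=O)ccc1OCCCN1CCC(C(c2ccccc2)c2ccc(F)cc2)CC1` gives 6.31 nM. Compound 2 `COc1cc(C(C)=O)ccc1OCCCN1CCC(C(c2ccc(F)cc2F)c2ccc(F)cc2F)CC1` gives 15.9 nM. Compound 3 `COc1cc(OCCCN2CCC(C(c3ccc(F)cc3)c3ccc(F)cc3)CC2)ccc1C(C)=O` gives 3.16 nM, the lowest of the three numbers, but its gap to compound 1 lies within the scatter, so the two cannot be ordered; only compound 2 stands clearly apart from it, with a number beyond the scatter.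

Compound 4 `Fc1ccc(C(c2ccc(F)cc2)C2CCN(CCCOc3ccccc3)CC2)cc1` has not yet been measured in this assay. It differs from compound 3 in one place: phenyl in place of 4-acetyl-3-methoxyphenyl on an oxygen on a saturated carbon. The 4-acetyl-3-methoxyphenyl group, which carries two hydrogen-bond acceptors and a double bond outside aromatic rings, is replaced by a bare phenyl with no acceptors at all, so the oxygen on the saturated carbon now carries only a plain phenoxy end.

Among the measured compounds shown here, no measured pair shows this change, so its size can only be guessed. Losing both acceptors on that ring is expected to cost some binding, giving a step from a 6.3-fold higher number from compound 3 to compound 4 (0.80 log units; beyond the scatter) toward a higher number beyond the scatter. Compound 4 is therefore estimated at 20 nM, with a range from 5 nM to 80 nM.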

Compound 4, dissociation constant: 1.59 nM
The estimate for compound 4 lay 13-fold (1.10 log units) above the measured number; measured number outside the range, below it.
By their numbers in this assay, from the lowest: compounds 4, 3 and 1 (each within the scatter of the next, the first and the last beyond it); then compound 2.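

In this assay, putting phenyl in place of 4-acetyl-3-methoxyphenyl on the oxygen gives a 2.0-fold lower number from compound 3 to compound 4 (0.30 log units; within the scatter), so compound 3 and compound 4 cannot be ordered. Compounds 1, 2 and 3 all carry the acetyl and methoxy groups on that ring, so they could not show what happens without them; compound 4 now shows that the number stays within the scatter of compound 3 even after that ring loses both groups and its two hydrogen-bond acceptors, which means this assay gives no sign that either group is needed at this position. No measurement shown explains why the number holds up once both groups are gone.

Still open, as far as these compounds go, is whether a ring with only the acetyl or only the methoxy would match the two compounds at either end of this step, and whether an amine or a carboxylic acid on the phenoxy ring would leave the number just as unmoved. Also open, from the compounds shown here alone, is whether a longer chain between that oxygen and the shared core would be accepted as readily as the present one.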